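Swapping Methoxyphenyl for Chlorophenyl in Compound 4

The compounds below may be only part of what the source reports. "The series", "measured", "known", "first", "only" and "open" are said of these compounds alone.

For the measured compounds named here, compound 2 `COc1ccc(/C=N/NC(=S)NC(C)(C)[C@H]2CC=C(C)CC2)cc1` is the only compound with a single number in a functional assay on UACC-62 cells (Homo sapiens) for inhibition, read by sulforhodamine B assay, with a stated time of 48 h (a higher number here means a weaker inhibitor of growth, a lower number a stronger inhibitor of growth), where compound 2 gives 70400 nM. Compound 3 `CC1=CC[C@H](C(C)(C)NC(=S)N/N=C/c2ccc(O)cc2)CC1` reaches only a limit of this assay, recorded as > 100000 nM. That limit is the limit of > 100000 nM in this assay, at which 1 of the 3 values shown sits. Compound 1 `CC1=CC[C@H](C(C)(C)NC(=S)NN)CC1` has no result in this assay, where compound 1 stands as "not determined" (no result reported). The step from compound 2 to compound 3 is an at least 1.4-fold higher number from compound 2 to compound 3 (0.15 log units; that floor lies within the scatter). Compound 4 `CC1=CC[C@H](C(C)(C)NC(=S)N/N=C/c2cccc(Cl)c2)CC1` differs from compound 2 by 3-chlorophenyl in place of 4-methoxyphenyl on a carbon with a double bond to nitrogen. Going by the values given here, the single measured step changes a different group, so no step beyond the scatter is expected here, and the estimated step of a 1.2-fold lower number from compound 2 to compound 4 (0.07 log units; within the scatter) is accordingly small. Compound 4 is therefore expected to give about 60000 nM in this assay, within 20000 nM to 150000 nM.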

Compound 4, concentration for total growth inhibition: 39800 nM
Beside the measured number, compound 4's estimate is 1.5-fold (0.18 log units) above it, and the stated range covers the measured number.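

In this assay, for the compounds shown here, replacing the group on a carbon with a double bond to nitrogen gives a step that the earlier compounds did not show, an at least 2.5-fold lower number from compound 3 to compound 4 (0.40 log units; beyond the scatter). The other new step, a 1.8-fold lower number from compound 2 to compound 4 (0.25 log units; within the scatter), does not separate 3-chlorophenyl from 4-methoxyphenyl at this position. Compound 3 stands at a limit of the assay: the limit of > 100000 nM in this assay, at which 1 of the 4 values shown sits.

The compounds shown leave open whether the lower number follows the chlorine itself or its place on the ring, since 3-chlorophenyl and 4-hydroxyphenyl differ in both. Going by these compounds, how an amine or a carboxylic acid on this aromatic ring would read also remains open.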